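Chromone acrylamides: a 4-methoxybenzyl replaces a 3-fluorobenzyl

This account rests on a few compounds, and the source may have more. Where it says the series, first, only, none or still open, it means among the compounds named here.

Compound 1 `COc1ccc2c(=O)c(/C=C/C(=O)NCc3cccc(F)c3)coc2c1`: 17600 nM
Compound 2 `Cc1ccccc1NC(=O)/C=C/c1coc2cc(O)ccc2c1=O`: 8670 nM
Compound 3 `O=C(/C=C/c1coc2cc(O)ccc2c1=O)NCc1ccccc1`: > 100000 nM

Of the compounds shown here, three sharing the core of compound 1 have been measured in a functional assay on HeLa cells (Homo sapiens) for inhibition, read by MTT assay, with a stated time of 48 h; a lower number here means a stronger inhibitor, a higher number a weaker inhibitor. Of the two plain numbers, compound 1 gives the higher one, and compound 2 the lower, a gap beyond the scatter. For compound 3 the value is a limit of the assay and not a number, (the limit of > 100000 nM in this assay, at which 1 of the 3 values shown sits). Among the compounds with values here, the one measured single-point step, an at least 11-fold higher number from compound 2 to compound 3 (1.06 log units; beyond the scatter), concerns a different amide substituent and a different core substituent, so it bears only loosely on the change from compound 1 to compound 4 `COc1ccc(CNC(=O)/C=C/c2coc3cc(OC)ccc3c2=O)cc1`: 4-methoxyphenyl in place of 3-fluorophenyl on a saturated chain carbon bound to an amide-type nitrogen. Within the data shown here, with no directly comparable step, compound 4 is expected to sit near compound 1, estimated at 25000 nM, between 8000 nM and 80000 nM, a step of a 1.4-fold higher number from compound 1 to compound 4 (0.15 log units; within the scatter).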

Compound 4, half-maximal inhibitory concentration: > 100000 nM
Compound 4: no number, only a limit; the forecaster's own chance of this, stated with the estimate: 25%; middle value at least 4.0-fold (0.60 log units) from the limit.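

With the rest of compound 1 unchanged, exchanging 3-fluorobenzyl for 4-methoxybenzyl gives an at least 5.6-fold higher number from compound 1 to compound 4 (0.75 log units; beyond the scatter) and is the only step shown at this position. The aryl group on this chain alone therefore separates a measurable value from the limit. Going by these compounds, the result for compound 4 is a limit of the assay and not a number, so the full size of the step remains unknown: the limit of > 100000 nM in this assay, at which 2 of the 4 values shown sit.

On these data alone, whether an amine or a carboxylic acid in this place would give a number remains open.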